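Chain Extension on the Hydrazone of Compound 3

The source may hold more compounds than are shown below. What is called first, only, known or untested is meant among the compounds shown, and "the series" means these compounds.

Compound 3 `CCC/C(CC)=N\Nc1nc(-c2cccc([N+](=O)[O-])c2)cs1` stands at the highest of the three numbers measured in an assay on isolated protein for inhibition of Amine oxidase [flavin-containing] B (Homo sapiens), read by fluorescence, with a stated time of 20 min (a higher number here means a weaker inhibitor, a lower number a stronger inhibitor), where compound 3 gives 189 nM. Compound 1 `CCC(CC)=NNc1nc(-c2cccc([N+](=O)[O-])c2)cs1` gives 53 nM in this assay, and compound 2 `CCCC/C(C)=N\Nc1nc(-c2cccc([N+](=O)[O-])c2)cs1` gives 118 nM. Compound 4 `CCCCC/C(CC)=N\Nc1nc(-c2cccc([N+](=O)[O-])c2)cs1` has not yet been measured; its difference from compound 3 is ethyl in place of hydrogen on a saturated chain carbon, three bonds along the chain from a carbon with a double bond to nitrogen. For the measured compounds named here, two measured steps bear on this change, both lengthening the same chain: a 3.6-fold higher number from compound 1 to compound 3 (0.55 log units; beyond the scatter) and a 2.2-fold higher number from compound 1 to compound 2 (0.35 log units; beyond the scatter). Both went toward a higher number, and the third pair, a 1.6-fold higher number from compound 2 to compound 3 (0.20 log units; within the scatter), did not reverse that. The longer chain in compound 4 is therefore expected to continue in the same direction, with a modest rise of about a 2.0-fold higher number from compound 3 to compound 4 (0.30 log units; within the scatter), though a step within the scatter cannot be excluded. Compound 4 is thus estimated to give 380 nM in this assay, within a range from 150 nM to 950 nM.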

Compound 4, half-maximal inhibitory concentration: 355 nM
Beside the measured number, compound 4's estimate is 1.1-fold (0.03 log units) above it, within the range that was stated.
By their numbers in this assay, from the lowest: compound 1; then compounds 2, 3 and 4 (each within the scatter of the next, the first and the last beyond it).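

Taken alone, ethyl in place of hydrogen at this place gives a 1.9-fold higher number from compound 3 to compound 4 (0.27 log units; within the scatter), so this last extension cannot be separated from repeat-to-repeat variation. Measured from the shorter chain of compound 1, however, propyl in place of hydrogen gives a 6.7-fold higher number from compound 1 to compound 4 (0.83 log units; beyond the scatter), the largest step in this small set and wider than either earlier step from compound 1. Across these four compounds, then, the change shows up over the whole extension rather than at its final addition, and no step from compound 1 goes against that direction. The compounds shown leave open whether a still longer chain, a cyclohexyl ring or an amine at the end of the chain would follow the same course. No supporting data here explain why the number follows the length of this chain.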